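The source may hold more compounds than are shown below. What is called first, only, known or untested is meant among the compounds shown, and "the series" means these compounds.

Measured so far in a functional assay on HGC-27 cells (Homo sapiens) for cytotoxicity, read by MTT assay, with a stated time of 72 h; a higher number here means a weaker inhibitor, a lower number a stronger inhibitor:
Compound 1 `CCOc1ccccc1Nc1nc(SCc2ccc(C(F)(F)F)cc2)nc2ccccc12` — the value for compound 1 is a limit of the assay, > 50000 nM.
Compound 2 `O=[N+]([O-])c1ccc(Nc2nc(SCc3ccc(C(F)(F)F)cc3)nc3ccccc23)cc1` — compound 2 gives 16600 nM.

For the measured compounds named here, compound 2 holds the only numerical value in this assay; the other value sits at a limit (the limit of > 50000 nM in this assay, at which 1 of the 2 values shown sits). Going by the values given here, the one measured step, an at least 3.0-fold lower number from compound 1 to compound 2 (0.47 log units; beyond the scatter), runs from an alkoxy-bearing phenyl to the nitrophenyl. Compound 3 `COc1cc(Nc2nc(SCc3ccc(C(F)(F)F)cc3)nc3ccccc23)cc(OC)c1` reverses toward an alkoxy pattern: 3,5-dimethoxyphenyl in place of 4-nitrophenyl on a nitrogen on an aromatic ring. That step bears only loosely on the change, but it points to a weaker value. Compound 3 is therefore expected to give 35000 nM, within 12000 nM to 100000 nM, an estimated step of a 2.1-fold higher number from compound 2 to compound 3 (0.32 log units; beyond the scatter).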

Compound 3, half-maximal inhibitory concentration: > 50000 nM
Compound 3: only a limit was reported; the forecaster's own chance of this, stated with the estimate: 40%; middle value at least 1.4-fold (0.15 log units) from the limit.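

Replacing 4-nitrophenyl with 3,5-dimethoxyphenyl on the nitrogen gives an at least 3.0-fold higher number from compound 2 to compound 3 (0.47 log units; beyond the scatter) in this assay. A second alkoxy-bearing phenyl therefore also ends at a limit of the assay, and the two limits leave the comparison between the alkoxy-bearing compounds unreadable. A numerical value on this nitrogen rests on compound 2 alone, with the other two at the limit: the limit of > 50000 nM in this assay, at which 2 of the 3 values shown sit.

Open, from the compounds shown here alone, is how a 4-aminophenyl or a 4-carboxyphenyl on this nitrogen would read. Also open, going by these compounds, is whether a numerical value needs the nitro group specifically.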